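Swapping a sulfanyl group for a bromothiazolyl amino group

A few compounds are considered here, and "the series" means these few. Any claim that something is new, unique, unknown or untested is made for them only; others in the source may bear on it.

compound 1 `Nc1ccccc1NC(=O)c1ccc(CNc2ncc(-c3ccc(Cl)cc3)s2)cc1` gives 300 nM
compound 2 `Cn1ccnc1SCc1ccc(C(=O)Nc2ccccc2N)cc1` gives 5000 nM

In a functional assay on HCT-116 cells (Homo sapiens) for cytotoxicity, read by MTT assay (a lower number here means a stronger inhibitor, a higher number a weaker inhibitor), compound 2 stands at 5000 nM and has the higher of the two numbers, with a gap to compound 1 that lies beyond the usual scatter. Compound 3 (`Nc1ccccc1NC(=O)c1ccc(CNc2ncc(Br)s2)cc1`) has not yet been measured. It differs from compound 2 in one place ((5-bromo-1,3-thiazol-2-yl)amino in place of (1-methyl-1H-imidazol-2-yl)sulfanyl on a saturated chain carbon bound to an aromatic carbon): (5-bromo-1,3-thiazol-2-yl)amino in place of (1-methyl-1H-imidazol-2-yl)sulfanyl on a saturated chain carbon bound to an aromatic carbon.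

Going by the values given here, no measured pair shows this change directly, so the evidence is thin. Compound 1 also carries a 1,3-thiazol-2-yl amino group and gives 300 nM in this assay; it has no bromine, however. The expected change is a 4.2-fold lower number from compound 2 to compound 3 (0.62 log units; beyond the scatter) (a lower number, beyond the scatter). For compound 3 the estimated value is 1200 nM (expected range 400 nM to 4000 nM).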

Compound 3, half-maximal inhibitory concentration: 400 nM
Compound 3: the middle estimate sits 3.0-fold (0.48 log units) above what was measured; the measured number falls inside the stated range.
By their numbers in this assay, from the lowest: compounds 1 and 3 (each within the scatter of the next); then compound 2.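

In this assay, (5-bromo-1,3-thiazol-2-yl)amino in place of (1-methyl-1H-imidazol-2-yl)sulfanyl on a saturated chain carbon bound to an aromatic carbon gives a 13-fold lower number from compound 2 to compound 3 (1.10 log units; beyond the scatter), so the outcome at this position depends strongly on the group it carries. Bromo in place of 4-chlorophenyl on an aromatic carbon gives a 1.3-fold higher number from compound 1 to compound 3 (0.12 log units; within the scatter), so this assay does not tell those two groups apart. Nothing available explains either result.

The first change replaces the ring, the sulfur link and the ring's substituents all at once, so these compounds leave open which of those parts accounts for the step. They also leave open what a methoxy group or a plain hydrogen in place of bromo would give.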